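A Second Chloro on the Anilide Ring of Compound 2

This account rests on a few compounds, and the source may have more. Where it says the series, first, only, none or still open, it means among the compounds named here.

Compound 1 `Cc1c(O)c(=O)ccn1CC(=O)N/N=C1\C(=O)N(CC(=O)Nc2ccc(Br)cc2)c2ccccc21`: 32500 nM
Compound 2 `Cc1c(O)c(=O)ccn1CC(=O)N/N=C1\C(=O)N(CC(=O)Nc2ccccc2Cl)c2ccccc21`: 46400 nM

In a functional assay on MCF7 cells (Homo sapiens) for cytotoxicity, read by MTT assay, with a stated time of 48 h (on this read-out higher numbers stand for an effect only at larger amounts of compound and lower numbers for an effect already at smaller amounts), compound 1 gives 32500 nM, and compound 2 gives 46400 nM. Compound 2 thus carries the higher of the two numbers, with compound 1 nearest to it, but the gap between them lies within the usual scatter. For the measured compounds named here, the only measured step, a 1.4-fold higher number from compound 1 to compound 2 (0.15 log units; within the scatter), goes with 2-chlorophenyl in place of 4-bromophenyl on an amide-type nitrogen.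

Compound 3 `Cc1c(O)c(=O)ccn1CC(=O)N/N=C1\C(=O)N(CC(=O)Nc2ccc(Cl)cc2Cl)c2ccccc21` differs from compound 2 by chloro in place of hydrogen on an aromatic carbon. Compound 3 therefore combines the halogen pattern of compound 2 with a further halogen of the kind compound 1 carries, so both measured compounds bear on it. Going by the values given here, because the only step between them, a 1.4-fold higher number from compound 1 to compound 2 (0.15 log units; within the scatter), stayed within the scatter, no movement beyond the scatter is expected in this assay. Compound 3 is expected to give 38000 nM, within 15000 nM to 95000 nM. The expected step is a 1.2-fold lower number from compound 2 to compound 3 (0.09 log units; within the scatter).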

Compound 3, half-maximal effective concentration: 43200 nM
Compound 3: the middle estimate sits 1.1-fold (0.06 log units) below what was measured; low and high end bracket the measured number.
By their numbers in this assay, from the lowest: compounds 1, 3 and 2 (each within the scatter of the next).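

In this assay, the added chloro, meta to a chloro group and para to a large group, gives a 1.1-fold lower number from compound 2 to compound 3 (0.03 log units; within the scatter), so this position on the 2-chlorophenyl ring accepts a second halogen without a shift beyond the scatter. Set against the 4-bromophenyl group, the 2,4-dichlorophenyl group gives a 1.3-fold higher number from compound 1 to compound 3 (0.12 log units; within the scatter), which means that the three halogen patterns shown on this ring all lie within the scatter of one another. Nothing available here bears on why these numbers stay so close.

As far as these compounds go, whether an amine or a carboxylic acid in place of this chloro would move the number beyond the scatter remains open. So does the effect of a methoxy group at the same position, since only halogens have been seen on this ring so far.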